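A few compounds are considered here, and "the series" means these few. Any claim that something is new, unique, unknown or untested is made for them only; others in the source may bear on it.

In a functional assay on HOS-TE85 cells (Homo sapiens) for inhibition, read by CCK-8 assay, with a stated time of 72 h (on this read-out lower numbers stand for stronger inhibition and higher numbers for weaker inhibition), compound 1 `O=C(NCCCCn1cccn1)c1cccc(C2SCC(=O)N2c2cc(Br)ccn2)c1` gives 105 nM. Compound 3 `COc1cc(F)ccc1N1C(=O)CSC1c1cccc(C(=O)NCCCCc2ccccc2)c1` gives 71.1 nM, a number within the usual scatter of that of compound 1 . Compound 2 `C#Cc1cc(C(=O)NCCCCc2ccccc2)cc(C2SCC(=O)N2c2ccccc2OC)c1` gives 40.8 nM, and it alone has a number lower than that of compound 1 by more than the scatter. Compound 1 therefore stands at the upper end of the numbers in this small set, together with compound 3 .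

Compound 4 `CCOC(=O)c1sc(N2C(=O)CSC2c2cccc(C(=O)NCCCCn3cccn3)c2)nc1C` differs from compound 1 in one place, on an amide-type nitrogen in a ring: 5-(ethoxycarbonyl)-4-methyl-1,3-thiazol-2-yl in place of 4-bromopyridin-2-yl on an amide-type nitrogen in a ring. In words, 5-(ethoxycarbonyl)-4-methyl-1,3-thiazol-2-yl stands in place of 4-bromopyridin-2-yl.

Within the data shown here, no pair of measured compounds differs in a single place, so the data offer no direct step to lean on. The expectation rests only on the narrow spread of the measured numbers, from compound 2 at 40.8 nM to compound 1 at 105 nM. In this assay, no step beyond the scatter is therefore expected, with a slight lean towards a higher number. The estimated step is a 1.2-fold higher number from compound 1 to compound 4 (0.08 log units; within the scatter). For compound 4 the expected value is 125 nM, with an estimated range from 40 nM to 400 nM.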

Compound 4, half-maximal inhibitory concentration: 430 nM
For compound 4 the middle estimate is 3.4-fold (0.54 log units) below the measured one, outside the stated range (above it).
By their numbers in this assay, from the lowest: compounds 2, 3 and 1 (each within the scatter of the next, the first and the last beyond it); then compound 4.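

In this assay, among these compounds, the group on the amide-type nitrogen in a ring turns out to matter: 5-(ethoxycarbonyl)-4-methyl-1,3-thiazol-2-yl in place of 4-bromopyridin-2-yl gives a 4.1-fold higher number from compound 1 to compound 4 (0.61 log units; beyond the scatter), the first single-place step in this set, and it lies beyond the scatter. This one step changes several things at once, replacing a six-membered aromatic ring with 1 hetero atom, 7 heavy atoms and 1 hydrogen-bond acceptor by a five-membered aromatic ring with 2 hetero atoms, 11 heavy atoms and 4 hydrogen-bond acceptors. No measurement at hand accounts for the higher number.

The compounds shown leave open whether the step follows from the ring itself or from its ethoxycarbonyl group, a question that a 1,3-thiazol-2-yl group with only the methyl group, or one carrying a carboxylic acid in place of the ester, would help to settle. They also leave open whether the same change would give a step of similar size on a compound with the amide chain of compound 3 in place of the chain of compound 1.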